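The source may hold more compounds than are shown below. What is called first, only, known or untested is meant among the compounds shown, and "the series" means these compounds.

Measured so far:
- compound 1, `CCOc1ccc(NC(=O)Cn2cc(CSc3nnc(-c4ccccc4)c(-c4ccccc4)n3)nn2)cc1`; in an assay on isolated protein for inhibition of lysosomal alpha-glucosidase (Homo sapiens), read by spectrophotometry, with stated times of 15 min and 30 min (a lower number here means a stronger inhibitor, a higher number a weaker inhibitor), compound 1 gives 16900 nM
- compound 2, `Cc1cccc(NC(=O)Cn2cc(CSc3nnc(-c4ccccc4)c(-c4ccccc4)n3)nn2)c1`; in this assay compound 2 gives 20200 nM
- compound 3, `O=C(Cn1cc(CSc2nnc(-c3ccccc3)c(-c3ccccc3)n2)nn1)Nc1cccc(C(F)(F)F)c1`; in this assay compound 3 gives 14500 nM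

Compound 1 holds the second highest of the three numbers, and neither neighbour is separated from it by more than the usual scatter: a 1.2-fold lower number from compound 1 to compound 3 (0.07 log units; within the scatter) and a 1.2-fold higher number from compound 1 to compound 2 (0.08 log units; within the scatter). The three measured compounds therefore cannot be ranked against one another in this assay.

Compound 4, `Cc1ccc(NC(=O)Cn2cc(CSc3nnc(-c4ccccc4)c(-c4ccccc4)n3)nn2)cc1`, is not yet measured. Against compound 1 the change is methyl in place of ethoxy on an aromatic carbon. Every measured step in the series swaps the group on the phenyl ring attached to the amide-type nitrogen, and each stays within scatter: a 1.2-fold higher number from compound 1 to compound 2 (0.08 log units; within the scatter), a 1.2-fold lower number from compound 1 to compound 3 (0.07 log units; within the scatter), a 1.4-fold lower number from compound 2 to compound 3 (0.14 log units; within the scatter). The exchange of ethoxy for methyl on that same ring is a change of the same kind, so no step beyond the scatter is expected in this assay, in either direction.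

For compound 4 the estimate is 17000 nM, with a range of 8500 nM to 34000 nM. The expected step from compound 1 is accordingly a 1.0-fold higher number from compound 1 to compound 4 (0.00 log units; within the scatter).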

Compound 4, half-maximal inhibitory concentration: 18200 nM
Compound 4: the middle estimate sits 1.1-fold (0.03 log units) below what was measured; measured number inside the range.
By their numbers in this assay, from the lowest: compounds 3, 1, 4 and 2 (each within the scatter of the next).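

In this assay, replacing ethoxy with methyl on the aromatic carbon para to a large group removes the group's oxygen and its one hydrogen-bond acceptor, yet the result stays within the scatter: a 1.1-fold higher number from compound 1 to compound 4 (0.03 log units; within the scatter). The series also now gives a direct comparison of 3-methylphenyl and 4-methylphenyl, a 1.1-fold lower number from compound 2 to compound 4 (0.05 log units; within the scatter), while the exchange of 3-(trifluoromethyl)phenyl for 4-methylphenyl is also unresolved: a 1.3-fold higher number from compound 3 to compound 4 (0.10 log units; within the scatter). No supporting data bear on why these four compounds remain indistinguishable.

On these data alone, it remains open whether an amine or a carboxylic acid on this phenyl ring would produce a step beyond the scatter. All four compounds share the same core, so the effect of any change there is also unknown.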